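Swapping the Tetrazole Substituent in a Lactam Series

A few compounds are considered here, and "the series" means these few. Any claim that something is new, unique, unknown or untested is made for them only; others in the source may bear on it.

For the measured compounds named here, compound 2 `CC(O)Cn1nnc(-c2ccccc2-c2ccc(CN3C(=O)[C@H](NC(=O)CC(C)(C)N)CCc4ccccc43)cc2)n1` gives 0.05 uM in a functional assay (Pituitary gland cell) with Rattus norvegicus as the target (a lower number here means that less compound is needed, a higher number that more compound is needed for the effect), the lowest of the two numbers measured so far; its nearest neighbour is compound 1 `CC(C)(N)CC(=O)N[C@@H]1CCc2ccccc2N(Cc2ccc(-c3ccccc3C(=O)O)cc2)C1=O`, which gives 3 uM in this assay. Going by the values given here, the only measured step, a 60-fold lower number from compound 1 to compound 2 (1.78 log units; beyond the scatter), exchanged a carboxy group on an aromatic carbon for a 2-(2-hydroxypropyl)-2H-tetrazol-5-yl group and brought a large gain. Compound 3 `Cn1nnnc1-c1ccccc1-c1ccc(CN2C(=O)[C@H](NC(=O)CC(C)(C)N)CCc3ccccc32)cc1` has not yet been measured. It differs from compound 2 by 1-methyl-1H-tetrazol-5-yl in place of 2-(2-hydroxypropyl)-2H-tetrazol-5-yl on an aromatic carbon: on an aromatic carbon of a six-membered aromatic ring of carbon only, ortho to a large group, the 2-hydroxypropyl chain gives way to a methyl group while the tetrazole itself stays. Among the compounds with values here, no measured step addresses this smaller exchange; the one measured step concerned the presence of the tetrazole, which compound 3 keeps. A step of modest size, if any, is therefore expected, most likely toward a somewhat higher number, a 2.0-fold higher number from compound 2 to compound 3 (0.30 log units; within the scatter). Compound 3 is expected to give about 0.1 uM in this assay, within a range from 0.03 uM to 0.4 uM.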

Compound 3, concentration for half-maximal effect: 0.5 uM
For compound 3 the middle estimate is 5.0-fold (0.70 log units) below the measured one; measured number outside the range, above it.
By their numbers in this assay, from the lowest: compound 2; then compound 3; then compound 1.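

The substituent on the tetrazole proves to matter as much as the tetrazole itself: in this assay, the exchange of 2-(2-hydroxypropyl)-2H-tetrazol-5-yl for 1-methyl-1H-tetrazol-5-yl, on an aromatic carbon ortho to a large group, gives a 10-fold higher number from compound 2 to compound 3 (1.00 log units; beyond the scatter), although both compounds carry the same kind of ring. Replacing carboxy with a tetrazole therefore does not have one fixed effect at this position, since 1-methyl-1H-tetrazol-5-yl gives only a 6.0-fold lower number from compound 1 to compound 3 (0.78 log units; beyond the scatter), a smaller gain than a 60-fold lower number from compound 1 to compound 2 (1.78 log units; beyond the scatter) seen with the hydroxypropyl-bearing tetrazole. Nothing available gives a reason for the size of these steps.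

This exchange alters two things at once, the 1H or 2H form named for the tetrazole and the chain it carries, so the compounds shown cannot say which of the two accounts for the step; a 2-methyl-2H-tetrazol-5-yl group or a 1-(2-hydroxypropyl)-1H-tetrazol-5-yl group would separate them. On these data alone, it also remains open whether the hydroxyl of the chain takes part at all, which a plain propyl chain, a longer chain ending in hydroxyl or a chain ending in an amine could test.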